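The source may report more compounds than this note shows. Statements on the series, on what has been measured and on what is new or still open speak of the compounds shown alone.

Measured compounds in a functional assay on MDA-MB-231 cells (Homo sapiens) for inhibition, read by MTT assay, with a stated time of 48 h; on this read-out higher numbers stand for weaker inhibition and lower numbers for stronger inhibition:

compound 1 `COc1cc(-c2cc(/C=C/C(=O)c3ccc(N)cc3)[nH]n2)cc(OC)c1OC` gives 2000 nM
compound 2 `COc1ccc2c(c1)C/C(=C\c1cc(-c3cc(OC)c(OC)c(OC)c3)n[nH]1)C2=O` gives 2000 nM
compound 3 `COc1cc(-c2cc(/C=C/C(=O)c3ccc(Cl)c(Cl)c3)[nH]n2)cc(OC)c1OC` gives 2100 nM

On these numbers compound 1 sits level with compound 2 at the digits shown, the two together at the low end of the three, and compound 3 lies within the scatter of both. Going by the values given here, the only single-point step among them, a 1.1-fold higher number from compound 1 to compound 3 (0.02 log units; within the scatter), swaps one ring for another on the carbonyl carbon and leaves the number essentially unchanged.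

Compound 4 `COc1cc(-c2cc(/C=C/C(C)=O)[nH]n2)cc(OC)c1OC` is reached from compound 1 by methyl in place of 4-aminophenyl on a carbonyl carbon. Among the compounds with values here, no measured step removes the ring on the carbonyl carbon altogether; the step from compound 1 to compound 3 shows only that exchanging one such ring for another stays within the scatter, so it bears on the new step only loosely. Within the data shown here, with no direct precedent, the expectation is a modest loss rather than a gain, with wide uncertainty: the step from compound 1 to compound 4 is estimated as a 2.0-fold higher number from compound 1 to compound 4 (0.30 log units; within the scatter). Compound 4 is therefore expected at about 4000 nM in this assay, within a range of 1500 nM to 12000 nM.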

Compound 4, half-maximal inhibitory concentration: 27300 nM
Compound 4: middle estimate off by 6.8-fold (0.83 log units), on the low side; the measured number lies above the stated range.
By their numbers in this assay, from the lowest: compounds 1, 2 and 3 (each within the scatter of the next); then compound 4.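

In this assay, the group on the carbonyl carbon proves far less tolerant of change than the ring-for-ring exchange suggested: methyl in place of 4-aminophenyl gives a 14-fold higher number from compound 1 to compound 4 (1.14 log units; beyond the scatter), and methyl in place of 3,4-dichlorophenyl gives a 13-fold higher number from compound 3 to compound 4 (1.11 log units; beyond the scatter). The two large steps end at the same compound and start from differently substituted rings, so in these compounds the loss follows the removal of the ring and not the identity of its substituents. Nothing available here gives a reason for this loss.

From the compounds shown here alone, it remains open whether a saturated ring such as cyclohexyl, or a longer chain such as n-hexyl, on the carbonyl carbon would hold the number or whether an aromatic ring is required. Also open, going by these compounds, is whether a carboxylic acid on the phenyl ring would be tolerated as the amine and the two chlorines are.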